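A few compounds are considered here, and "the series" means these few. Any claim that something is new, unique, unknown or untested is made for them only; others in the source may bear on it.

Measured compounds:
Compound 1 `Cc1cc(N2CC[C@@H](C)[C@@H](N(C)c3ncnc4[nH]ccc34)C2)n2nc(SCc3ccc(F)cc3)nc2n1`: in a functional assay on HGC-27 cells (Homo sapiens) for inhibition, read by MTT assay, with a stated time of 72 h (a higher number here means a weaker inhibitor, a lower number a stronger inhibitor), compound 1 gives 26000 nM.
Compound 2 `Cc1cc(N2CC[C@@H](C)[C@@H](N(C)c3ncnc4[nH]ccc34)C2)n2nc(SCC3CCCCC3)nc2n1`: in this assay compound 2 gives 11500 nM.

Within the data shown here, of these two numbers, compound 1 has the higher one, which in this read-out means the weaker inhibitor; compound 2 is its only neighbour, and the single measured step, a 2.3-fold lower number from compound 1 to compound 2 (0.35 log units; beyond the scatter), is modest but lies beyond the scatter.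

Compound 3 `C#CSc1nc2nc(C)cc(N3CC[C@@H](C)[C@@H](N(C)c4ncnc5[nH]ccc45)C3)n2n1` has not yet been measured. Its difference from compound 1 is ethynyl in place of 4-fluorobenzyl on a sulfur. Among the measured compounds shown here, the one measured step, from compound 1 to compound 2, swaps one ring for another of similar size on the chain carbon bound to the sulfur. Here, instead, the whole 4-fluorobenzyl group is replaced by ethynyl bound directly to the sulfur. For the measured compounds named here, no measured pair shows what such a large loss of atoms does, so the measured step gives only weak guidance.

Given that compound 1 already sits at the weak end, and that the change removes most of the group, compound 3 is expected to stay weak or become weaker still, with a 1.5-fold higher number from compound 1 to compound 3 (0.19 log units; within the scatter) estimated. The estimate for compound 3 is 40000 nM, within a range from 12000 nM to 130000 nM.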

Compound 3, half-maximal inhibitory concentration: 35100 nM
Beside the measured number, compound 3's estimate is 1.1-fold (0.06 log units) above it; low and high end bracket the measured number.
By their numbers in this assay, from the lowest: compound 2; then compounds 1 and 3 (each within the scatter of the next).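

Replacing 4-fluorobenzyl with ethynyl on this sulfur removes the aromatic ring and most of the group's heavy atoms, yet the outcome in this assay is a 1.4-fold higher number from compound 1 to compound 3 (0.13 log units; within the scatter) and so cannot be told apart from no change. At this position, then, a large benzyl group and a small ethynyl group give readings that cannot be ranked against each other. Cyclohexylmethyl on the same sulfur does stand apart, with a 3.1-fold higher number from compound 2 to compound 3 (0.48 log units; beyond the scatter) as a modest step, and among these three compounds only compound 2 is separated from the others. No other measurement is available to account for these numbers.

The compounds shown leave open whether any group on this sulfur can bring the number down further than cyclohexylmethyl does, and a longer alkyl chain or a chain ending in an amine would begin to test that. They also cannot say whether the lower number of compound 2 depends on the cyclohexyl ring itself, a question that a cyclopentylmethyl group or an open hexyl chain in the same place could address.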